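What a silicon-bearing group may do to compound 1

A few compounds are considered here, and "the series" means these few. Any claim that something is new, unique, unknown or untested is made for them only; others in the source may bear on it.

Measured compounds:
compound 1 `COc1ccc(C2=C(c3cc(OC)c(OC)c(OC)c3)C(=O)CC2O)cc1O`: < 1 ug/mL (a limit)
compound 2 `COc1ccc(C2=C(c3cc(OC)c(OC)c(OC)c3)C(=O)CC2O)cc1`: 10 ug/mL
compound 3 `COc1ccc(C2=C(c3cc(OC)c(OC)c(OC)c3)CC(O[SiH2]C(C)(C)C)C2=O)cc1[N+](=O)[O-]`: > 100 ug/mL (a limit)

The readings come from an ADME assay on L132 cells (Homo sapiens) for cytotoxicity, read by MTT assay, with a stated time of 72 h (on this read-out higher numbers stand for weaker inhibition and lower numbers for stronger inhibition), and span a wide range. Compound 1 is known only by a limit, (the limit of < 1 ug/mL in this assay, at which 1 of the 3 values shown sits), and it stands at the strong end of the values shown. Compound 4 `COc1ccc(C2=C(c3cc(OC)c(OC)c(OC)c3)C(=O)CC2O[SiH2]C(C)(C)C)cc1O` keeps the core of compound 1 and differs in one change: a group of 5 heavy atoms (4 carbon, 1 silicon; no ring) in place of a hydrogen atom, on an oxygen on a saturated carbon.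

Among the measured compounds shown here, no measured step touches that oxygen. For the measured compounds named here, the only measured step, an at least 10-fold higher number from compound 1 to compound 2 (1.00 log units; beyond the scatter), lies at another place, and it shows that this series can move well beyond the scatter on one small edit. Going by the values given here, compound 3, the only measured compound that also holds this group on an oxygen, is likewise known only by a limit, (the limit of > 100 ug/mL in this assay, at which 1 of the 3 values shown sits). That reading is a loose guide, yet it points toward weaker inhibition, so a move in that direction is expected in this assay, with its size poorly fixed. The expected change is an at least 5.0-fold higher number from compound 1 to compound 4 (0.69 log units; beyond the scatter). Compound 4 is estimated at 5 ug/mL, with an expected range from 0.7 ug/mL to 50 ug/mL.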

Compound 4, half-maximal inhibitory concentration: < 1 ug/mL
Compound 4: a limit, no number; the forecaster's own chance of this, stated with the estimate: 35%; middle value at least 5.0-fold (0.69 log units) from the limit.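

Among the compounds shown here, compound 1 and compound 4 are each known only by a limit, and no step between them can be read, because both readings rest on the same limit: the limit of < 1 ug/mL in this assay, at which 2 of the 4 values shown sit.

The compounds shown leave open how far each of the two lies past that limit, and whether the silicon-bearing group on the oxygen changes the reading at all.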